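Swapping methyl for chloro on compound 1

The source may hold more compounds than are shown below. What is called first, only, known or untested is meant among the compounds shown, and "the series" means these compounds.

Measured in an ADME assay on MT4 cells (Homo sapiens) for cytotoxicity, read by MTT assay; on this read-out higher numbers stand for lower toxicity in this test and lower numbers for higher toxicity in this test:
Compound 1 `Cc1ccccc1NC(=O)CSc1nncnc1-c1ccccc1Cl` gives 142000 nM
Compound 2 `CC(=O)c1ccc(NC(=O)CSc2nncnc2-c2cccc3ccccc23)c(Br)c1` gives 133000 nM
Compound 3 `O=C(CSc1nncnc1-c1cccc2ccccc12)Nc1ccccc1Cl` gives 63000 nM

Compound 1 and compound 2 sit together within the scatter, while compound 3 lies lower, beyond it. The next compound to be tested is compound 4 `O=C(CSc1nncnc1-c1ccccc1Cl)Nc1ccccc1Cl`, which differs from compound 1 by one change: chloro in place of methyl on an aromatic carbon. Here chloro takes the place of methyl on an aromatic carbon, ortho to a large group, so 2-methylphenyl becomes 2-chlorophenyl.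

Among the measured compounds shown here, one measured step bears on this: a 2.1-fold lower number from compound 2 to compound 3 (0.32 log units; beyond the scatter). That step also ends in 2-chlorophenyl on an amide-type nitrogen, but it replaces a different group on a different core, so it is only a loose guide. It points downward, and a swap of one heavy atom is expected to move the number less. In this assay the expected change is a 1.5-fold lower number from compound 1 to compound 4 (0.17 log units; within the scatter), which may not clear the scatter. For compound 4 the estimated value is 95000 nM, with an expected range from 45000 nM to 200000 nM.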

Compound 4, half-maximal cytotoxic concentration: 90000 nM
Compound 4: middle estimate off by 1.1-fold (0.02 log units), on the high side, within the range that was stated.
By their numbers in this assay, from the lowest: compounds 3, 4, 2 and 1 (each within the scatter of the next, the first and the last beyond it).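

In this assay, among the compounds shown here, this is the first step that changes only the group on the amide-type nitrogen's ring while the rest of the molecule stays fixed: with chloro in place of methyl on an aromatic carbon, the step is a 1.6-fold lower number from compound 1 to compound 4 (0.20 log units; within the scatter), and this lies within the scatter. On this core, then, the swap of one heavy atom at this position gives no difference that can be told apart from repeat-measurement variation, whereas the earlier step to 2-chlorophenyl replaced a much larger group on a different core. Nothing measured here offers an explanation for this result.

On these data alone, it remains open whether an amine, a carboxylic acid or a longer chain such as propyl on this aromatic carbon would move the number beyond the scatter. The same swap from 2-methylphenyl to 2-chlorophenyl also remains to be read on the core of compound 3.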